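Trifluoromethyl to Methyl: Expected Effect on Inhibition

This account rests on a few compounds, and the source may have more. Where it says the series, first, only, none or still open, it means among the compounds named here.

Measured so far:
compound 1 `O=C(N1CCC(c2nc(-c3ccc4ccccc4n3)no2)CC1)N1CCCc2ccccc21` — 2300 nM in a functional assay on Shh Light II cells (Mus musculus) for inhibition, read by a luciferase reporter; on this read-out lower numbers stand for stronger inhibition and higher numbers for weaker inhibition
compound 2 `O=C(Nc1ccccc1C(F)(F)F)N1CCC(c2nc(-c3ccc4ccccc4n3)no2)CC1` — 700 nM in this assay

Compound 2 holds the lower of the two numbers in this assay; its nearest neighbour is compound 1, and the step of a 3.3-fold lower number from compound 1 to compound 2 (0.52 log units; beyond the scatter) lies beyond the scatter. Compound 3 `Cc1ccccc1NC(=O)N1CCC(c2nc(-c3ccc4ccccc4n3)no2)CC1` has not yet been measured. It differs from compound 2 in one place: methyl in place of trifluoromethyl on an aromatic carbon. Within the data shown here, no measured step bears directly on this change; the only step known, a 3.3-fold lower number from compound 1 to compound 2 (0.52 log units; beyond the scatter), replaces the whole group on the carbonyl carbon rather than one substituent on the aromatic ring, and gives no guide to exchanging trifluoromethyl for methyl. The change is expected to bring at most a small step, a 1.4-fold higher number from compound 2 to compound 3 (0.15 log units; within the scatter), toward a weaker number. Compound 3 is therefore estimated at 1000 nM, with a range from 400 nM to 2500 nM.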

Compound 3, half-maximal inhibitory concentration: 440 nM
The estimate for compound 3 lay 2.3-fold (0.36 log units) above the measured number, within the range that was stated.
By their numbers in this assay, from the lowest: compounds 3 and 2 (each within the scatter of the next); then compound 1.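

In this assay, methyl in place of trifluoromethyl on this aromatic carbon gives a 1.6-fold lower number from compound 2 to compound 3 (0.20 log units; within the scatter), so exchanging a group of four heavy atoms for a single carbon leaves no difference that can be told from the scatter at this position. The (2-methylphenyl)amino group in place of 1,2,3,4-tetrahydroquinolin-1-yl on the carbonyl carbon gives a 5.2-fold lower number from compound 1 to compound 3 (0.72 log units; beyond the scatter), so the separation from compound 1 seen with the trifluoromethyl compound also holds with methyl. No evidence is available to explain these results.

The compounds shown leave open how a bare hydrogen, a chlorine or a methoxy group would read on this same aromatic carbon. They also leave open whether an amine or a carboxylic acid would be accepted there.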